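Chloro Next to the Ring Nitrogen: Compound 4

The compounds below may be only part of what the source reports. "The series", "measured", "known", "first", "only" and "open" are said of these compounds alone.

Measured so far in an in vitro functional assay on 1321-N1 cells for agonist activity at Free fatty acid receptor 1 (Homo sapiens), read by fluorescence, spectrophotometry and calcium flux; on this read-out higher numbers stand for larger maximal responses and lower numbers for smaller maximal responses:
- compound 1 `O=C(O)CCc1ccc(C#Cc2cccnc2)cc1` gives 96%
- compound 2 `Cc1ccccc1-c1cc(C#Cc2ccc(CCC(=O)O)cc2)ccn1` gives 92%
- compound 3 `Cc1c(C#Cc2ccc(CCC(=O)O)cc2)ccnc1Cl` gives 101%

All three values lie within the usual scatter of one another, and compound 1 sits among them with neither compound 2 nor compound 3 set apart from it beyond that scatter. Compound 4 `O=C(O)CCc1ccc(C#Cc2cccnc2Cl)cc1` is not yet measured. It differs from compound 1 by chloro in place of hydrogen on an aromatic carbon. Among the measured compounds shown here, no two measured compounds differ in a single place, so no measured step bears directly on this change. Compound 3, which also carries a chloro on an aromatic carbon next to the ring nitrogen, gives 101%, so a large shift is not expected. The step of a number 1 percentage points higher from compound 1 to compound 4 (within the scatter) is expected to stay within the scatter. Compound 4 is estimated at 97%, in the range 82% to 110%.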

Compound 4, largest response reached (reported as efficacy), in percent of the reference or control that the assay uses: 91%
Compound 4: the middle estimate sits 6 percentage points above what was measured; the range from low to high includes it.
By their numbers in this assay, from the lowest: compounds 4, 2, 1 and 3 (each within the scatter of the next).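

In this assay, chloro in place of hydrogen on an aromatic carbon, next to the ring nitrogen and ortho to a large group, gives a number 5 percentage points lower from compound 1 to compound 4 (within the scatter). Among the compounds shown here, this is the only single-place step so far, and it shows that this position accepts a chlorine atom while the maximal response stays within the scatter. Nothing measured here speaks to a cause of this result.

As far as these compounds go, whether a methyl, a methoxy or an amine at this same carbon would also keep the response remains open. So does whether chloro on other carbons of this ring would behave alike.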